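The compounds below may be only part of what the source reports. "The series", "measured", "known", "first", "only" and "open" are said of these compounds alone.

Measured so far:
Compound 1, `FC(F)(F)c1ccc(Sc2ccc(NC3=NCCN3)cc2)cc1`, gives 50.1 nM in an assay (Rattus norvegicus) for binding affinity to prostacyclin receptor (Homo sapiens), read by radioligand binding; a lower number here means a stronger inhibitor, a higher number a weaker inhibitor.
Compound 2, `COc1ccc(Sc2ccc(CC3=NCCN3)cc2)cc1`, gives 5010 nM in this assay.
Compound 3, `COc1ccc(Sc2ccc(C(=N)N)cc2)cc1`, gives 1260 nM in this assay.

Compound 3 stands second highest of the three numbers: compound 1 sits well below it, and the only change among these three that alters one place at a time is the step from compound 2 to compound 3, where a 4.0-fold lower number from compound 2 to compound 3 (0.60 log units; beyond the scatter).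

Compound 4, `COc1ccc(Sc2ccc(CN3CCCC3)cc2)cc1`, takes the next step from compound 3: a group of 6 heavy atoms (5 carbon, 1 nitrogen; one five-membered non-aromatic ring with 1 hetero atom) in place of a group of 3 heavy atoms (1 carbon, 2 nitrogen; no ring), on an aromatic carbon. Among the compounds with values here, the one step that bears on this is the one just named, and it ran the other way, from a ring-bearing group on that aromatic carbon to a small group of three heavy atoms, with a modest drop in the number. Going back to a ring-bearing group, though a different one with a single hetero atom and no hydrogen-bond donors, is therefore expected to raise the number again, by roughly a modest amount, though the new group is not the one of compound 2, so the size is uncertain.

Compound 4 is thus estimated at 8000 nM, within a range of 2000 nM to 30000 nM, which means an expected step of a 6.3-fold higher number from compound 3 to compound 4 (0.80 log units; beyond the scatter).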

Compound 4, inhibition constant: 10000 nM
The estimate for compound 4 lay 1.3-fold (0.10 log units) below the measured number; the range from low to high includes it.
By their numbers in this assay, from the lowest: compound 1; then compound 3; then compounds 2 and 4 (each within the scatter of the next).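

In this assay, the (pyrrolidin-1-yl)methyl group on this aromatic carbon gives up what the small ring-free group of compound 3 offered (a 7.9-fold higher number from compound 3 to compound 4 (0.90 log units; beyond the scatter)), so a second, different ring-bearing group now stands on the weaker side of compound 3. Exchanging the ring on the saturated chain carbon, with one ring nitrogen in place of two, gives (a 2.0-fold higher number from compound 2 to compound 4 (0.30 log units; within the scatter)), so this pair cannot separate the two rings. Among compounds 2, 3 and 4, the ring-free group therefore goes with the lowest number, whereas compound 1 carries a ring-bearing group and has a lower number still, though it differs from these compounds in more than one place. Nothing available explains these differences.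

Going by these compounds, it remains open whether the ring itself matters or whether an open-chain group on the same saturated carbon, such as dimethylaminomethyl, would behave like compound 4. A carboxylic acid on this aromatic carbon would show how far the trend among these compounds extends beyond nitrogen-containing groups.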